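The source may report more compounds than this note shows. Statements on the series, on what has been measured and on what is new or still open speak of the compounds shown alone.

Measured compounds:
compound 1 `CN1CCN(C(=O)/C=C/c2ccncc2-c2ccc3ccccc3c2)CC1` — > 30000 nM
compound 2 `O=C(/C=C/c1ccncc1-c1ccc2[nH]ccc2c1)N1CCOCC1` — "not determined" (no result reported)

In a functional assay on HCT-116 cells (Homo sapiens) for inhibition, read by MTT assay, with a stated time of 72 h (on this read-out higher numbers stand for weaker inhibition of growth and lower numbers for stronger inhibition of growth), compound 1 gives > 30000 nM, which is a limit of the assay rather than a measured number, as the limit of > 30000 nM in this assay, at which 1 of the 2 values shown sits, shows. Compound 2 has no result in this assay, only "not determined" (no result reported). Compound 3 `O=C(/C=C/c1ccncc1-c1ccc2ccccc2c1)N1CCOCC1` differs from compound 1 in one place: morpholin-4-yl in place of 4-methylpiperazin-1-yl on a carbonyl carbon. Within the data shown here, with no measured step between compounds to lean on, the change is expected to move compound 3 by a step that the limit leaves unreadable from compound 1 to compound 3 in this assay, a step not beyond the usual scatter. Compound 3 is therefore estimated at 40000 nM, with a range from 10000 nM to 120000 nM.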

Compound 3, concentration for 50% growth inhibition: 6040 nM
The estimate for compound 3 lay 6.6-fold (0.82 log units) above the measured number; measured number below the stated range.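

In this assay the change on the carbonyl carbon gives an at least 4.9-fold lower number from compound 1 to compound 3 (0.69 log units; beyond the scatter) and so shows that growth inhibition at this place depends on which six-membered ring is attached to the shared core. Morpholin-4-yl also gives this place its first single number. Compound 1 carries a limit, not a number, so the full size of the step remains unread: the limit of > 30000 nM in this assay, at which 1 of the 3 values shown sits.

On these data alone, whether piperidin-1-yl or an open-chain amine such as dimethylamino on the same carbonyl carbon would give a lower number than morpholin-4-yl remains open.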